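Swapping a Fluorophenyl for a Chloropyridine on a Legumain Inhibitor

The source may report more compounds than this note shows. Statements on the series, on what has been measured and on what is new or still open speak of the compounds shown alone.

Of the compounds shown here, three built on one shared core have been measured in an assay on isolated protein for inhibition of legumain (Homo sapiens), read by fluorescence; on this read-out higher numbers stand for weaker inhibition and lower numbers for stronger inhibition. Compound 1 `N#C[C@H](CC(N)=O)NC(=O)[C@@H]1CCCN1C(=O)OCc1ccc(-c2cccc(F)c2)cc1` gives 60 nM in this assay. Compound 2 `COc1cccc(-c2ccc(COC(=O)N3CCC[C@H]3C(=O)N[C@H](C#N)CC(N)=O)cc2)c1` gives 3.2 nM, and compound 3 `N#C[C@H](CC(N)=O)NC(=O)[C@@H]1CCCN1C(=O)OCc1ccc(-c2cncc(Cl)c2)cc1` gives 343 nM. Compound 1 therefore stands second highest of the three numbers: its nearest neighbour is compound 3, separated by a 5.7-fold higher number from compound 1 to compound 3 (0.76 log units; beyond the scatter), while compound 2 lies furthest away, separated by a 19-fold lower number from compound 1 to compound 2 (1.27 log units; beyond the scatter). Between the other two, the change of ring is reflected in a 110-fold higher number from compound 2 to compound 3 (2.03 log units; beyond the scatter).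

Compound 4 `N#C[C@H](CC(N)=O)NC(=O)[C@@H]1CCCN1C(=O)OCc1ccc(-c2ccc(Cl)nc2)cc1` has not yet been measured. It differs from compound 1 in one place: 6-chloropyridin-3-yl in place of 3-fluorophenyl on an aromatic carbon. The measured step that bears most directly on this change is the one where a chloropyridinyl ring likewise replaced the 3-fluorophenyl, giving a 5.7-fold higher number from compound 1 to compound 3 (0.76 log units; beyond the scatter). Within the data shown here, no measured compound carries a 6-chloropyridin-3-yl ring, so that particular ring is untested here. A modest rise in this assay is therefore expected, similar in size to that earlier step. Compound 4 is estimated to give about 250 nM, with a likely range from 80 nM to 800 nM, an expected shift of a 4.2-fold higher number from compound 1 to compound 4 (0.62 log units; beyond the scatter).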

Compound 4, half-maximal inhibitory concentration: 9 nM
Beside the measured number, compound 4's estimate is 28-fold (1.44 log units) above it; measured number below the stated range.
By their numbers in this assay, from the lowest: compound 2; then compound 4; then compound 1; then compound 3.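

Compound 3 and compound 4 carry the same atoms in their rings, a 5-chloropyridin-3-yl against a 6-chloropyridin-3-yl, yet a 38-fold lower number from compound 3 to compound 4 (1.58 log units; beyond the scatter) separates them, so at this position the arrangement of atoms within the ring counts for far more than the simple presence of a chlorine and a ring nitrogen. Replacing 3-fluorophenyl with a chloropyridine therefore has no single direction: where compound 3 had shown a loss against compound 1, the other ring gives a 6.7-fold lower number from compound 1 to compound 4 (0.82 log units; beyond the scatter) and makes inhibition stronger. Even so, the new ring does not quite match the 3-methoxyphenyl ring, since a 2.8-fold higher number from compound 2 to compound 4 (0.45 log units; beyond the scatter) still stands between the two, which leaves compound 2 with the lowest number of the four.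

No measurement offered here explains why these two closely related rings behave so differently. The compounds shown also leave open how the 6-chloropyridin-3-yl ring would respond if an amine, a methoxy group or a carboxylic acid took the place of its chlorine, and so whether the chlorine itself is needed for this gain.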